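Ring exchange from compound 3 to compound 4

A few compounds are considered here, and "the series" means these few. Any claim that something is new, unique, unknown or untested is made for them only; others in the source may bear on it.

Measured in an ADME assay on microsomes from liver (Rattus norvegicus) for metabolic stability (a higher number here means that the compound lasts longer, a lower number that the compound disappears faster), each value a limit:
- compound 1 `N#Cc1ccc(-c2nc(NCCNc3ccc([N+](=O)[O-])c(N)n3)ncc2-c2ncc[nH]2)cc1`: > 0.5 h (limit)
- compound 2 `Nc1nc(NCCNc2ncc(-c3ncc[nH]3)c(-c3ccc(F)cc3Br)n2)ccc1[N+](=O)[O-]`: > 0.5 h (limit)
- compound 3 `Nc1nc(NCCNc2ncc(-c3ncc[nH]3)c(-c3cc(F)c(Cl)cc3F)n2)ccc1[N+](=O)[O-]`: > 0.5 h (limit)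

Compound 3 stands at > 0.5 h, which is a limit and not a number. It has no readable place in the series, since the evidence is the limit of > 0.5 h in this assay, at which 3 of the 3 values shown sit, and nothing separates the three compounds.

Compound 4 `Nc1nc(NCCNc2ncc(-c3ncc[nH]3)c(-c3ccc(Cl)cc3Br)n2)ccc1[N+](=O)[O-]` carries 2-bromo-4-chlorophenyl in place of 4-chloro-2,5-difluorophenyl on an aromatic carbon, next to the ring nitrogen: 2-bromo-4-chlorophenyl in place of 4-chloro-2,5-difluorophenyl on an aromatic carbon.

Among the measured compounds shown here, three measured steps bear on this exchange: a step that the two limits leave unreadable from compound 1 to compound 2, a step that the two limits leave unreadable from compound 1 to compound 3 and a step that the two limits leave unreadable from compound 2 to compound 3. None offers a size or a direction to carry over. Compound 2, with the related 2-bromo-4-fluorophenyl group, gives > 0.5 h, also a limit. No step beyond the scatter is therefore expected in this assay, and no direction is expected either.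

The expected change is a step that the limit leaves unreadable from compound 3 to compound 4.

For compound 4 the estimated half-life is 0.6 h, with an expected range from 0.35 h to 1 h.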

Compound 4, half-life: > 0.5 h
Compound 4: a limit, no number (the forecaster's own chance of this, stated with the estimate: 80%); the middle value does not contradict the limit.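

No new step can be read between compound 4 and compound 1, compound 2 or compound 3 in this assay, since all four values are limits and not numbers: the limit of > 0.5 h in this assay, at which 4 of the 4 values shown sit.

As far as these compounds go, how long each compound actually lasts, and whether the exchanged groups alter it, stays open.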